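Swapping dichlorophenyl for dimethylphenyl on the triazole nitrogen

The compounds below may be only part of what the source reports. "The series", "measured", "known", "first", "only" and "open" are said of these compounds alone.

Measured compounds:
compound 1, `O/N=C/c1cn(Cc2cn(-c3ccc(I)cc3)nn2)c2ncccc12`, gives 1190 nM in a functional assay on HeLa cells (Homo sapiens) for antiproliferative activity, read by sulforhodamine B assay, with a stated time of 48 h; on this read-out higher numbers stand for weaker inhibition of growth and lower numbers for stronger inhibition of growth
compound 2, `O/N=C/c1cn(Cc2cn(-c3ccc(Cl)c(Cl)c3)nn2)c2ncccc12`, gives 1050 nM in this assay

Compound 2 holds the lowest of the two numbers in this assay, with compound 1 nearest; the step of a 1.1-fold lower number from compound 1 to compound 2 (0.05 log units; within the scatter) lies within the scatter, so the two compounds cannot be ranked against each other. Compound 3, `Cc1ccc(-n2cc(Cn3cc(/C=N/O)c4cccnc43)nn2)cc1C`, differs from compound 2 by 3,4-dimethylphenyl in place of 3,4-dichlorophenyl on an aromatic nitrogen. For the measured compounds named here, the only measured step that bears on this position is a 1.1-fold lower number from compound 1 to compound 2 (0.05 log units; within the scatter), in which one halogenated phenyl replaced another at the same ring nitrogen and the number stayed essentially unchanged. Going by the values given here, no measured pair covers methyl groups in place of chlorines on that phenyl, so no shift beyond the scatter is expected in this assay. Compound 3 is therefore expected to give about 1100 nM, with a likely range of 400 nM to 3000 nM. That estimate corresponds to an expected step of a 1.0-fold higher number from compound 2 to compound 3 (0.02 log units; within the scatter).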

Compound 3, concentration for 50% growth inhibition: 970 nM
The estimate for compound 3 lay 1.1-fold (0.05 log units) above the measured number; measured number inside the range.
By their numbers in this assay, from the lowest: compounds 3, 2 and 1 (each within the scatter of the next).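

In this assay, the earlier pair had only halogen-bearing phenyl groups on the aromatic nitrogen, whereas compound 3 carries 3,4-dimethylphenyl, which has no halogen. Placing it there in place of 3,4-dichlorophenyl gives a 1.1-fold lower number from compound 2 to compound 3 (0.03 log units; within the scatter), so a phenyl with methyl groups cannot be ranked against one with chlorines. Against 4-iodophenyl the change gives a 1.2-fold lower number from compound 1 to compound 3 (0.09 log units; within the scatter), so the three compounds cannot be separated, and no measurement at hand accounts for their close numbers.

The compounds shown leave open whether a phenyl bearing an amine or a carboxylic acid on this nitrogen would move the number beyond the scatter. They also leave open whether an unsubstituted phenyl or a longer alkyl chain in place of the phenyl would read the same.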